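This account rests on a few compounds, and the source may have more. Where it says the series, first, only, none or still open, it means among the compounds named here.

Measured compounds, all tested in a functional assay on HCT-116 cells (Homo sapiens) for antiproliferative activity, read by MTT assay, with a stated time of 24 h; on this read-out higher numbers stand for weaker inhibition and lower numbers for stronger inhibition:

- Compound 1, `COc1cc(OC)c(OC)cc1/C=C/C(=O)c1ccc(OC)c2c1OC(C)(C)C=C2`: compound 1 reaches only the assay limit, > 10000 nM.
- Compound 2, `COc1ccc(C(=O)/C=C/c2cccc(F)c2)c2c1C=CC(C)(C)O2`: compound 2 likewise reaches only the assay limit, > 10000 nM.
- Compound 3, `COc1ccc(C(=O)/C=C/c2ccc3ccccc3n2)c2c1C=CC(C)(C)O2`: compound 3 gives 4530 nM.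

All three share the same core, differing only in the aromatic group attached through the carbonyl-linked double bond. Compound 2 stands at the limit of this assay, so no number is known for it; it sits with compound 1 there, as noted in the limit of > 10000 nM in this assay, at which 2 of the 3 values shown sit, while compound 3 is the only one of the three with a measured value.

Compound 4, `COc1ccc(C(=O)/C=C/c2cccc(Cl)c2)c2c1C=CC(C)(C)O2`, is the next compound to be measured in this assay. It differs from compound 2 in one place: chloro in place of fluoro on an aromatic carbon. Cut one bond further out, this reads 3-fluorophenyl to 3-chlorophenyl, the halogen sitting meta to a large group.

For the measured compounds named here, no measured pair shows a step of this kind, so the expectation rests on compound 2 alone, which sits at the limit with > 10000 nM. With only one small halogen exchanged, the expected step that the limit leaves unreadable from compound 2 to compound 4 is small, and within the scatter. Compound 4 is therefore estimated at 15000 nM, with a range from 5000 nM to 40000 nM, and most likely again reported only as a limit.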

Compound 4, half-maximal inhibitory concentration: > 10000 nM
Compound 4: a limit, no number (the forecaster's own chance of this, stated with the estimate: 70%); the middle value is on the limit's open side.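

Compound 4 reaches only a limit in this assay, > 10000 nM. Compound 2 also stands at a limit, so no step can be read between compound 2 and compound 4: the limit of > 10000 nM in this assay, at which 3 of the 4 values shown sit.

The compounds shown leave open whether chloro in place of fluoro changes antiproliferative activity at all, with no actual number for compound 2 or compound 4.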